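A few compounds are considered here, and "the series" means these few. Any claim that something is new, unique, unknown or untested is made for them only; others in the source may bear on it.

Measured so far in a functional assay on HCT-116 cells (Homo sapiens) for cytotoxicity, read by MTT assay, with a stated time of 72 h; a higher number here means a weaker inhibitor, a lower number a stronger inhibitor:

- compound 1, `COc1ncc(-c2ccc3nccc(-c4ccc(C)cc4)c3c2)cc1NS(=O)(=O)c1ccc(F)cc1F`: 2540 nM
- compound 2, `CCN(Cc1ccc(-c2ccnc3ccc(-c4cnc(OC)c(NS(=O)(=O)c5ccc(F)cc5F)c4)cc23)cc1)C1CCCCC1`: 223 nM
- compound 3, `COc1ncc(-c2ccc3nccc(-c4ccc(CN5CCCCC5)cc4)c3c2)cc1NS(=O)(=O)c1ccc(F)cc1F`: 34.1 nM

Compound 3 gives the lowest number of the three in this assay. Its nearest neighbour is compound 2, separated by a 6.5-fold lower number from compound 2 to compound 3 (0.82 log units; beyond the scatter); its furthest is compound 1, separated by a 74-fold lower number from compound 1 to compound 3 (1.87 log units; beyond the scatter). Compound 2 itself is separated from compound 1 by an 11-fold lower number from compound 1 to compound 2 (1.06 log units; beyond the scatter).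

Compound 4, `COc1ncc(-c2ccc3nccc(-c4ccc(CN5CCN(C(C)C)CC5)cc4)c3c2)cc1NS(=O)(=O)c1ccc(F)cc1F`, is not yet measured. It differs from compound 3 by 4-isopropylpiperazin-1-yl in place of piperidin-1-yl on a saturated chain carbon bound to an aromatic carbon.

Going by the values given here, the steps that bear on this change are those at the same saturated chain carbon. Both amine replacements of hydrogen there, from compound 1 to compound 2 and from compound 1 to compound 3, gave large drops in the number, and the exchange of one amine for another, from compound 2 to compound 3, gave a modest drop. The change to compound 4 again exchanges one cyclic amine for another, so the number is expected to stay near that of compound 3, with the step of a 1.2-fold higher number from compound 3 to compound 4 (0.07 log units; within the scatter) expected to fall within the scatter or only a little beyond it. Compound 4 is therefore estimated at 40 nM, with a range from 14 nM to 120 nM.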

Compound 4, half-maximal inhibitory concentration: 24.7 nM
Compound 4: the middle estimate sits 1.6-fold (0.21 log units) above what was measured, within the range that was stated.
By their numbers in this assay, from the lowest: compounds 4 and 3 (each within the scatter of the next); then compound 2; then compound 1.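

In this assay the exchange on the saturated chain carbon bound to an aromatic carbon gives a 1.4-fold lower number from compound 3 to compound 4 (0.14 log units; within the scatter), so 4-isopropylpiperazin-1-yl, with 9 heavy atoms and 2 nitrogens, cannot be told from piperidin-1-yl, with 6 heavy atoms and 1 nitrogen. At this position the added size and the second ring nitrogen thus leave the number within the scatter, while 4-isopropylpiperazin-1-yl stands clearly apart from cyclohexyl(ethyl)amino, with a 9.0-fold lower number from compound 2 to compound 4 (0.96 log units; beyond the scatter), and from hydrogen, with a 100-fold lower number from compound 1 to compound 4 (2.01 log units; beyond the scatter). No measured property of these groups is available to account for these steps.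

The compounds shown leave open whether the isopropyl group contributes anything, which piperazin-1-yl with a hydrogen on the second ring nitrogen, or a methyl group there, would test, and whether the second nitrogen can be replaced by the oxygen of morpholin-4-yl. They also leave open whether any nitrogen is needed at this carbon, a question that a cyclohexyl group in place of the amine would address, and how a longer chain between the aromatic ring and the amine would read in this assay.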